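Swapping the Ester Group: From Compound 2 to Compound 3

A few compounds are considered here, and "the series" means these few. Any claim that something is new, unique, unknown or untested is made for them only; others in the source may bear on it.

Going by the values given here, in an ADME assay on HepG2 2.2.15 cells (Homo sapiens) for cytotoxicity (on this read-out higher numbers stand for lower toxicity in this test and lower numbers for higher toxicity in this test), compound 2 `CC(=O)N1CCC(C(=O)OCCc2c(-c3ccccc3Cl)c3cc(Cl)ccc3[nH]c2=O)CC1` gives 82000 nM, the lowest of the two numbers measured so far; compound 1 `O=c1[nH]c2ccc(Cl)cc2c(-c2ccccc2Cl)c1CCO` gives 380000 nM. Compound 3 `O=C(/C=C/c1ccccc1)OCCc1c(-c2ccccc2Cl)c2cc(Cl)ccc2[nH]c1=O` differs from compound 2 in one place: 2-phenylethenyl in place of 1-acetylpiperidin-4-yl on a carbonyl carbon. Among the compounds with values here, the one measured step, a 4.6-fold lower number from compound 1 to compound 2 (0.67 log units; beyond the scatter), came from placing (1-acetylpiperidin-4-yl)carbonyl in place of hydrogen on an oxygen on a saturated carbon, and no step compares two different groups on that carbonyl carbon. A modest further drop is expected, a 1.6-fold lower number from compound 2 to compound 3 (0.21 log units; within the scatter). Compound 3 is estimated at 50000 nM, within 15000 nM to 160000 nM.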

Compound 3, half-maximal cytotoxic concentration: 230000 nM
Compound 3: the middle estimate sits 4.6-fold (0.66 log units) below what was measured, outside the stated range (above it).
By their numbers in this assay, from the lowest: compound 2; then compounds 3 and 1 (each within the scatter of the next).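

The group on this carbonyl carbon matters in this assay: 2-phenylethenyl gives a 2.8-fold higher number from compound 2 to compound 3 (0.45 log units; beyond the scatter) and so shows that an ester on this oxygen does not always bring the drop seen with compound 2. With (2-phenylethenyl)carbonyl in place of hydrogen, the result is a 1.7-fold lower number from compound 1 to compound 3 (0.22 log units; within the scatter) and this ester cannot be told apart from the parent alcohol here. No measurement shown explains the difference between the two groups. Still open, as far as these compounds go, is how an ester ending in a free amine or a carboxylic acid, or one with a plain longer carbon chain, would behave at this position.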